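Trading 3-fluorophenyl for 4-methylphenyl on a sulfur

This account rests on a few compounds, and the source may have more. Where it says the series, first, only, none or still open, it means among the compounds named here.

In a functional assay on A-375 cells (Homo sapiens) for inhibition, read by CCK-8 assay, with a stated time of 72 h, tested at 8 uM (a higher number here means more inhibition of growth at the concentration tested, a lower number less inhibition of growth), compound 2 `Nc1ccccc1NC(=O)c1ccc(CSc2cccc(F)c2)cc1` gives 76.3%, and compound 1 `CCc1ccc(SCc2ccc(C(=O)Nc3ccccc3N)cc2)cc1` gives 71.1%. Going by the values given here, these two numbers lie within the scatter of each other, so compound 2 stands level with the only other compound measured so far.

Compound 3 `Cc1ccc(SCc2ccc(C(=O)Nc3ccccc3N)cc2)cc1` has not yet been measured. It carries 4-methylphenyl in place of 3-fluorophenyl on a sulfur whose other neighbour is a saturated chain carbon: 4-methylphenyl in place of 3-fluorophenyl on a sulfur.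

Among the compounds with values here, only one measured step bears on this change. It is a number 5.2 percentage points higher from compound 1 to compound 2 (within the scatter), where 3-fluorophenyl replaced 4-ethylphenyl on the same sulfur. That single exchange of groups at this place stayed inside the scatter, and the 4-methylphenyl of compound 3 resembles the 4-ethylphenyl of compound 1, which gives 71.1%. No step beyond the scatter is therefore expected in this assay.

The estimated change is a number 3.3 percentage points lower from compound 2 to compound 3 (within the scatter). Compound 3 is expected at 73%, with an estimated range of 62% to 83%.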

Compound 3, percent growth inhibition at one concentration: 67%
Compound 3: the middle estimate sits 6 percentage points above what was measured; low and high end bracket the measured number.
By their numbers in this assay, from the lowest: compounds 3, 1 and 2 (each within the scatter of the next).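

In this assay, going by these compounds alone, the exchange of 3-fluorophenyl for 4-methylphenyl on the sulfur gives a number 9.3 percentage points lower from compound 2 to compound 3 (within the scatter) and so, like the first exchange at this place, does not leave the usual scatter. The smaller edit within the alkyl group, hydrogen in place of methyl on a saturated chain carbon bound to an aromatic carbon, gives a number 4.1 percentage points lower from compound 1 to compound 3 (within the scatter) and so does not separate 4-ethylphenyl from 4-methylphenyl. All three compounds therefore stand level within each step shown, and no available measurement offers an explanation for the small differences in their numbers.

On these data alone, it remains open whether a group of another kind on the phenyl ring, such as an amine, a carboxylic acid or a longer chain such as butyl, would produce a step beyond the scatter. Also open, as far as these compounds go, is whether the sulfur itself matters, since all three compounds keep it, and whether an oxygen or a methylene group in its place would leave the percent growth inhibition where it stands.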